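Acetyl in place of dimethylamino: from compound 1 to compound 4

A few compounds are considered here, and "the series" means these few. Any claim that something is new, unique, unknown or untested is made for them only; others in the source may bear on it.

Among the compounds with values here, compound 1 `COc1cc(C)cc(-c2c(-c3ccnc(-c4ccc(N(C)C)cc4)c3)cnn2CC#N)c1` gives 302 nM in a functional assay on SF-268 cells (Homo sapiens) for inhibition, read by sulforhodamine B assay, with a stated time of 48 h (on this read-out lower numbers stand for stronger inhibition of growth and higher numbers for weaker inhibition of growth), the lowest of the three numbers so far. Compound 2 `Cc1cc(O)cc(-c2nn(CC#N)cc2-c2ccnc(-c3ccc(Oc4ccccc4)cc3)c2)c1` gives 3960 nM in this assay, and compound 3 `COc1cc(C)cc(-c2nn(CC#N)cc2-c2ccc(-c3cccc(C(C)=O)c3)nc2)c1` gives 4070 nM; both gaps from compound 1 lie beyond the scatter, and none of these pairs differs in one place only. Compound 4 `COc1cc(C)cc(-c2c(-c3ccnc(-c4ccc(C(C)=O)cc4)c3)cnn2CC#N)c1` is not yet measured. Its difference from compound 1: acetyl in place of dimethylamino on an aromatic carbon. Within the data shown here, no measured pair shows this change. Compound 3 also carries an acetyl and sits at 4070 nM, though it is not a one-place neighbour of compound 1. A moderate weakening beyond the scatter is expected, a 3.0-fold higher number from compound 1 to compound 4 (0.47 log units; beyond the scatter). Compound 4 is estimated near 900 nM, with a range from 300 nM to 3000 nM.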

Compound 4, concentration for 50% growth inhibition: 3140 nM
For compound 4 the middle estimate is 3.5-fold (0.54 log units) below the measured one, and the stated range ends below it.
By their numbers in this assay, from the lowest: compound 1; then compounds 4, 2 and 3 (each within the scatter of the next).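

In this assay the change from 4-(dimethylamino)phenyl to 4-acetylphenyl gives a 10-fold higher number from compound 1 to compound 4 (1.02 log units; beyond the scatter) and is a large step, so this position is sensitive to which group it carries. The two groups have the same count of heavy atoms and of hydrogen-bond acceptors, so those counts do not separate them. Nothing available accounts for the size of the step.

Open, on these data alone, is whether a primary amine, a methoxy group or a carboxylic acid at this place would stay near compound 1 or near compound 4. Also open, as far as these compounds go, is whether the step recurs on a different core.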